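Pyridazinone-fused bicyclic series: aryl swap at the amide nitrogen

This account rests on a few compounds, and the source may have more. Where it says the series, first, only, none or still open, it means among the compounds named here.

Measured compounds:
compound 1 `COc1ccc(N2NC3=CC[C@@H](OC)O[C@@]3(c3ccccc3)CC2=O)cc1` – 8400 nM
compound 2 `CO[C@@H]1CC=C2NN(c3ccc(Cl)cc3)C(=O)C[C@]2(C)O1` – 28700 nM

Compound 2 gives the higher of the two numbers recorded so far, and its gap to compound 1 lies beyond the scatter. Compound 3 `CO[C@@H]1CC=C2NN(c3cccnc3)C(=O)C[C@]2(C)O1` carries the change pyridin-3-yl in place of 4-chlorophenyl on an amide-type nitrogen in a ring on the shared core of compound 2. Within the data shown here, no step between measured compounds covers such a swap, so the expectation rests on compound 2 alone. In a functional assay on SK-BR-3 cells (Homo sapiens) for inhibition, read by sulforhodamine B assay, with a stated time of 48 h (on this read-out lower numbers stand for stronger inhibition and higher numbers for weaker inhibition), a small step, if any, is expected, tending toward a higher number; the estimated step is a 1.4-fold higher number from compound 2 to compound 3 (0.14 log units; within the scatter). Compound 3 is accordingly expected near 40000 nM, with a range from 12000 nM to 130000 nM.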

Compound 3, half-maximal inhibitory concentration: 15200 nM
Estimate against measurement, compound 3: 2.6-fold (0.42 log units) above; the range from low to high includes it.
By their numbers in this assay, from the lowest: compounds 1, 3 and 2 (each within the scatter of the next, the first and the last beyond it).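

In this assay, pyridin-3-yl in place of 4-chlorophenyl on the amide-type nitrogen in a ring gives a 1.9-fold lower number from compound 2 to compound 3 (0.28 log units; within the scatter), the first step read at this position. The exchange of a carbon-only aromatic ring bearing chlorine for one with a ring nitrogen therefore does not move the number beyond the scatter. No available evidence bears on the reason for this result.

Compound 1 differs from compound 2 in more than one place, so its gap cannot be assigned to a single change. As far as these compounds go, whether an amine or a carboxylic acid on the ring at this position would shift the number remains open.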